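The compounds below may be only part of what the source reports. "The series", "measured", "known", "first", "only" and "open" are said of these compounds alone.

Compound 1 `CC(C)(C)NCc1c(C(=O)O)nn(-c2ccccc2)c1-c1ccc(F)cc1` in a functional assay on PC-3 cells (Homo sapiens) for inhibition, read by sulforhodamine B assay, with a stated time of 48 h; a higher number here means a weaker inhibitor of growth, a lower number a stronger inhibitor of growth: > 680000 nM, a limit.
Compound 2 `CC(C)(C)NCc1c(C(=O)O)nn(-c2ccccc2)c1-c1ccc(Br)cc1` in this assay: > 585000 nM, a limit.
Compound 3 `COc1ccc(-c2c(CNC(C)(C)C)c(C(=O)O)nn2-c2ccccc2)cc1` in this assay: > 659000 nM, a limit.

Compound 3 has no number in this assay, and neither do the other two measured compounds, so it cannot be ranked among them. Compound 4 `CC(C)(C)NCc1c(C(=O)O)nn(-c2ccccc2)c1-c1ccc([N+](=O)[O-])cc1` carries nitro in place of methoxy on an aromatic carbon, para to a large group: nitro in place of methoxy on an aromatic carbon. Three measured swaps on an aromatic carbon bear on this: a step that the two limits leave unreadable from compound 1 to compound 3, a step that the two limits leave unreadable from compound 2 to compound 3 and a step that the two limits leave unreadable from compound 1 to compound 2. None has a readable size, so no step beyond the scatter and no direction is expected in this assay. The expected outcome is an at least 1.0-fold lower number from compound 3 to compound 4 (0.01 log units; that floor lies within the scatter). The estimate for compound 4 is 630000 nM, with an expected range of 350000 nM to 800000 nM, most likely reported again as a limit.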

Compound 4, concentration for 50% growth inhibition: > 634000 nM
Compound 4 gave a limit, no number (the forecaster's own chance of this, stated with the estimate: 85%); at least 1.0-fold (0.00 log units) between middle value and limit.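

Among the compounds shown here, compound 1, compound 2, compound 3 and compound 4 all give limits, not numbers, in this assay, and no step among them can be read. The compounds shown leave open how these four rank and whether any of these aromatic substituents changes growth inhibition.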